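The compounds below may be only part of what the source reports. "The series", "measured", "known", "first", "only" and "open" are said of these compounds alone.

Measured compounds:
- compound 1, `CC1=NN(S(=O)(=O)c2ccc(C)cc2)C(c2cc(Br)cc(Br)c2O)C1`, 51200 nM
- compound 2, `O=C(c1ccccc1Cl)N1N=C(c2cc3ccccc3oc2=O)CC1c1ccccc1`, 6370 nM

Of the compounds shown here, two have been tested in a functional assay on PC-3 cells (Homo sapiens) for cytotoxicity, read by MTT assay, with a stated time of 48 h; on this read-out lower numbers stand for stronger inhibition and higher numbers for weaker inhibition. Compound 1 gives 51200 nM in this assay, while compound 2 gives 6370 nM, the lower of the two numbers; the gap between them lies beyond the scatter of the method, so compound 2 stands as the stronger inhibitor of the pair. The two compounds share no single-point relationship, so nothing can be said about what separates them.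

Compound 3, `NC(=O)C1CCN(CC(=O)N2N=C(c3cc4ccccc4oc3=O)CC2c2ccccc2)CC1`, has not yet been measured in this assay. It differs from compound 2 in one place: (4-carbamoylpiperidin-1-yl)methyl in place of 2-chlorophenyl on a carbonyl carbon. For the measured compounds named here, no measured pair in this set speaks to a change of this kind, so the size of the step from compound 2 to compound 3 cannot be read from the data. The expectation is that the step is small, at most a modest move toward a higher number, and likely within the scatter: a 1.4-fold higher number from compound 2 to compound 3 (0.15 log units; within the scatter) is expected. Compound 3 is accordingly estimated at 9000 nM, with a range from 3000 nM to 30000 nM.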

Compound 3, half-maximal inhibitory concentration: 8310 nM
Compound 3: middle estimate off by 1.1-fold (0.03 log units), on the high side, and the stated range covers the measured number.
By their numbers in this assay, from the lowest: compounds 2 and 3 (each within the scatter of the next); then compound 1.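

At the carbonyl carbon whose other neighbour is the amide-type nitrogen in a ring, putting (4-carbamoylpiperidin-1-yl)methyl in place of 2-chlorophenyl gives, in this assay, a 1.3-fold higher number from compound 2 to compound 3 (0.12 log units; within the scatter). For the compounds shown here, this is the first comparison in the set between compounds that differ in one place, and it shows that this position can take two very different groups without a change beyond the scatter: the six-membered aromatic ring of carbon only and the chlorine leave, while a six-membered non-aromatic ring with a hetero atom, a hydrogen-bond donor and hydrogen-bond acceptors enter. No independent measurement bears on why the two groups read alike.

Going by these compounds, a single pair cannot show whether this holds for the position in general, so it remains open how a plain methyl or an unsubstituted phenyl on that carbonyl carbon would read. On these data alone, it is equally open whether a carboxylic acid in place of the carbamoyl part, or a morpholine in place of the piperidine ring, would keep the number within the scatter of compound 2.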